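A 4-Ethoxyphenyl Amide Expected to Stay Inactive

The source may hold more compounds than are shown below. What is called first, only, known or untested is meant among the compounds shown, and "the series" means these compounds.

Compound 1 `O=C(NCc1ccccc1)c1cccc(/C=C2\CC(=O)N(c3ccccc3)C2=O)c1`: in an ADME assay on HCT-116 cells (Homo sapiens) for cytotoxicity, read by MTT assay, with a stated time of 72 h (on this read-out higher numbers stand for weaker inhibition and lower numbers for stronger inhibition), compound 1 gives > 100000 nM, which is a limit of the assay and not a number.
Compound 2 `COc1cc(NC(=O)c2cccc(/C=C3\CC(=O)N(c4ccccc4)C3=O)c2)cc(OC)c1OC`: in this assay compound 2 gives > 100000 nM, again only a limit.
Compound 3 `COc1ccc(NC(=O)c2cccc(/C=C3\CC(=O)N(c4ccc(C)cc4)C3=O)c2)cc1`: in this assay compound 3 gives > 100000 nM, also a limit.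

Compound 1 therefore stands nowhere in particular on a scale: it sits at the limit of > 100000 nM in this assay, at which 3 of the 3 values shown sit, and so does every other value shown. No two of these compounds can be ordered against each other, and no measured step exists between any pair.

Compound 4 `CCOc1ccc(NC(=O)c2cccc(/C=C3\CC(=O)N(c4ccccc4)C3=O)c2)cc1` differs from compound 1 in one place: 4-ethoxyphenyl in place of benzyl on an amide-type nitrogen. Compounds 2 and 3 also carry an aromatic ring directly on the amide nitrogen, and both give only the limit in this assay. With nothing in the data pointing to any growth-inhibiting activity, the expected step that the limit leaves unreadable from compound 1 to compound 4 is none beyond the usual scatter. Compound 4 is estimated at 150000 nM, within 60000 nM to 400000 nM, and is expected to be reported again as a limit rather than a number.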

Compound 4, half-maximal inhibitory concentration: 84800 nM
Beside the measured number, compound 4's estimate is 1.8-fold (0.25 log units) above it, within the range that was stated.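

Going by these compounds alone, compound 4 is the first compound here to give a real number rather than a limit in this assay, so 4-ethoxyphenyl in place of benzyl on an amide-type nitrogen gives a value that can be read. The change amounts to an at least 1.1-fold lower number from compound 1 to compound 4 (0.07 log units; that floor lies within the scatter), so this floor alone does not establish a real gain. The true size of the step stays unknown because compound 1 has only a limit, and most of the series sits there too: the limit of > 100000 nM in this assay, at which 3 of the 4 values shown sit.

The compounds shown do not separate the effect of removing the benzyl carbon link from that of adding the ethoxy group, since this one change does both. As far as these compounds go, it also remains open whether an amine, a carboxylic acid or a longer chain such as butoxy in place of ethoxy on the phenyl ring would move the value further from the limit.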